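The source may hold more compounds than are shown below. What is called first, only, known or untested is meant among the compounds shown, and "the series" means these compounds.

Three compounds have been measured in a functional assay, read by Griess assay, with a stated time of 150 min, tested at 100 ug/mL; on this read-out lower numbers stand for a weaker effect and higher numbers for a stronger effect at the one concentration tested:

compound 1, `Cc1ccc(C2CNN=C2S(=O)(=O)CC2=NCCS2)cc1`, with 52.2%
compound 2, `COc1ccc(C2=NOC(c3ccc(C)cc3)C2S(=O)(=O)CC2=NCCO2)cc1`, with 71.3%
compound 3, `Cc1ccc(C2CNN=C2S(=O)(=O)CC2=NCCO2)cc1`, with 51.4%

Compounds 3 and 1 share a core and differ in one place: a group of 5 heavy atoms (3 carbon, 1 nitrogen, 1 sulfur; one five-membered non-aromatic ring with 2 hetero atoms) in place of a group of 5 heavy atoms (3 carbon, 1 nitrogen, 1 oxygen; one five-membered non-aromatic ring with 2 hetero atoms), on a saturated chain carbon bound to a sulfonyl sulfur. That exchange gave a number 0.8 percentage points higher from compound 3 to compound 1 (within the scatter), so the two rings behave alike on this core. Compound 2 stands highest of the three in this assay; its steps to compound 1 and to compound 3 both lie beyond the scatter. How the core of compound 2 differs from the core of compound 3 is not broken down here.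

Compound 4, `COc1ccc(C2=NOC(c3ccc(C)cc3)C2S(=O)(=O)CC2=NCCS2)cc1`, has not yet been measured in this assay. It differs from compound 2 by a group of 5 heavy atoms (3 carbon, 1 nitrogen, 1 sulfur; one five-membered non-aromatic ring with 2 hetero atoms) in place of a group of 5 heavy atoms (3 carbon, 1 nitrogen, 1 oxygen; one five-membered non-aromatic ring with 2 hetero atoms), on a saturated chain carbon bound to a sulfonyl sulfur, the same change already seen from compound 3 to compound 1. Because a number 0.8 percentage points higher from compound 3 to compound 1 (within the scatter) was within the scatter, the expected step from compound 2 to compound 4 is likewise small, estimated at a number 0.7 percentage points higher from compound 2 to compound 4 (within the scatter). Compound 4 is therefore expected to give about 72% in this assay, within an estimated range from 60% to 84%.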

Compound 4, a percentage reported as activity, at one concentration (the size of the read-out at that concentration, not a potency): 59.6%
Compound 4: the middle estimate sits 12.4 percentage points above what was measured; measured number below the stated range.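

In this assay, putting the five-membered non-aromatic ring holding sulfur in place of the one holding oxygen, on a saturated chain carbon bound to a sulfonyl sulfur, gave a number 11.7 percentage points lower from compound 2 to compound 4 (beyond the scatter). Set beside the earlier step, this one does not separate from it: the same change on two cores in this assay, a number 0.8 percentage points higher (within the scatter) from compound 3 to compound 1 and a number 11.7 percentage points lower (beyond the scatter) from compound 2 to compound 4, 12.5 percentage points apart, within the scatter of two such steps. Going by these compounds alone, the two pairs therefore do not show that the change acts differently on the two cores, but with only one pair on each core they do not show that it carries over unchanged either.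

The compounds shown leave open how a third core would respond to this same exchange, since the comparison rests on two cores alone. They also leave open how this assay would read with an imidazoline ring, an open-chain amine or a carboxylic acid on that same chain carbon.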